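The source may hold more compounds than are shown below. What is called first, only, known or untested is meant among the compounds shown, and "the series" means these compounds.

Measured so far:
- Compound 1 `O=C(c1ccc2c(c1)OCCO2)C1CCN(Cc2coc(-c3ccc(F)cc3)n2)CC1`: in an ADME assay on HEK293 cells (Homo sapiens) for cytotoxicity, read by MTT assay, with a stated time of 36 h (on this read-out higher numbers stand for weaker inhibition and lower numbers for stronger inhibition), compound 1 gives > 150 ug/mL, which is a limit of the assay.
- Compound 2 `O=C(c1ccc(F)c(F)c1)C1CCN(Cc2coc(-c3ccc(F)cc3)n2)CC1`: in this assay compound 2 gives > 150 ug/mL, again a limit.
- Compound 3 `Cc1ccc(C(=O)C2CCN(Cc3coc(-c4ccc(F)cc4)n3)CC2)cc1C`: in this assay compound 3 gives > 150 ug/mL, also a limit.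

Compound 3 therefore stands nowhere in particular on the numbers shown: all three values sit at the limit of > 150 ug/mL in this assay, at which 3 of the 3 values shown sit, and no ordering among the three can be read. The steps a step that the two limits leave unreadable from compound 1 to compound 2, a step that the two limits leave unreadable from compound 1 to compound 3 and a step that the two limits leave unreadable from compound 2 to compound 3 are each unreadable for the same reason.

Compound 4 `COc1ccc(C(=O)C2CCN(Cc3coc(-c4ccc(F)cc4)n3)CC2)cc1OC` is the next member. Its change from compound 3 is 3,4-dimethoxyphenyl in place of 3,4-dimethylphenyl on a carbonyl carbon. The three measured steps all exchange the aryl group on the carbonyl carbon, and every one of them leaves the value at the limit, so no size or direction can be assigned to them. No step beyond the scatter is expected here because the limit of > 150 ug/mL in this assay, at which 3 of the 3 values shown sit, holds for every aryl variation measured so far. The expected step is a step that the limit leaves unreadable from compound 3 to compound 4, meaning compound 4 is expected to give another limit. Compound 4 is estimated at 200 ug/mL, with a range from 100 ug/mL to 400 ug/mL.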

Compound 4, half-maximal inhibitory concentration: > 150 ug/mL
Compound 4 gave a limit, no number; the forecaster's own chance of this, stated with the estimate: 85%; the middle value does not contradict the limit.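

No step from compound 1, compound 2 or compound 3 to compound 4 can be read in this assay, because compound 4 also gives only a limit: the limit of > 150 ug/mL in this assay, at which 4 of the 4 values shown sit.

The compounds shown leave open how these aryl groups on the carbonyl carbon rank in this assay, and where the half-maximal concentration of each compound lies.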